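Ring nitrogen substituent: methyl to cyclohexyl

This account rests on a few compounds, and the source may have more. Where it says the series, first, only, none or still open, it means among the compounds named here.

Measured so far:
compound 1 `CC(C)c1onc(-c2c(Cl)cccc2Cl)c1COc1ccc(-c2nc3ccc(C(=O)O)cc3n2C)cc1`: 7150 nM
compound 2 `CC(C)c1onc(-c2c(Cl)cccc2Cl)c1COc1ccc(-c2nc3ccc(C(=O)O)cc3n2C2CC2)cc1`: 3200 nM

In an assay on HEK-293T cells for antagonist activity at vitamin D3 receptor (Homo sapiens), read by a luciferase reporter, with a stated time of 24 h (a lower number here means a stronger inhibitor, a higher number a weaker inhibitor), compound 1 gives 7150 nM, the highest of the two numbers shown; compound 2 gives 3200 nM. Compound 3 `CC(C)c1onc(-c2c(Cl)cccc2Cl)c1COc1ccc(-c2nc3ccc(C(=O)O)cc3n2C2CCCCC2)cc1` differs from compound 1 as follows: cyclohexyl in place of methyl on an aromatic nitrogen. Going by the values given here, the only measured step that bears on this change is a 2.2-fold lower number from compound 1 to compound 2 (0.35 log units; beyond the scatter), where a ring likewise replaced the methyl on the aromatic nitrogen. A step in the same direction, of modest size, is therefore expected for compound 3, namely a 2.0-fold lower number from compound 1 to compound 3 (0.31 log units; beyond the scatter). Compound 3 is estimated at 3500 nM, with a range from 1200 nM to 10000 nM.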

Compound 3, half-maximal inhibitory concentration: 1450 nM
Estimate against measurement, compound 3: 2.4-fold (0.38 log units) above; measured number inside the range.
By their numbers in this assay, from the lowest: compound 3; then compound 2; then compound 1.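

On the aromatic nitrogen in this assay, cyclohexyl goes further than the smaller ring: there is a 4.9-fold lower number from compound 1 to compound 3 (0.69 log units; beyond the scatter) and also a 2.2-fold lower number from compound 2 to compound 3 (0.34 log units; beyond the scatter), so the two rings are separated beyond the scatter. Across these three compounds the number falls from methyl through cyclopropyl to cyclohexyl, and none of them goes against that order. Nothing available here explains this order.

As far as these compounds go, whether the number keeps falling with a cycloheptyl ring remains open. So does whether ring size matters more than carbon count, which an open chain such as hexyl or a piperidine ring would test.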